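The compounds below may be only part of what the source reports. "The series", "measured", "known", "first", "only" and "open" are said of these compounds alone.

Measured compounds:
compound 1, `C=C(Br)C(=O)Nc1cccc(-c2cn3nc(-c4ccc(C)cc4)sc3n2)c1`: 920 nM
compound 2, `Nc1cccc(-c2cn3nc(-c4ccc(F)cc4)sc3n2)c1`: >= 250000 nM

The account concerns two measured compounds and one that is yet to be tested. Going by the values given here, in a functional assay on L1210 cells (Mus musculus) for inhibition, read by cell counting, with a stated time of 2 days (a lower number here means a stronger inhibitor, a higher number a weaker inhibitor), compound 1 gives 920 nM, and this is the only actual number in the set. Compound 2 does not give a number at all; its result is a limit of the assay, namely (the limit of >= 250000 nM in this assay, at which 1 of the 2 values shown sits). Compound 1 therefore stands alone as the single measured point of reference, with compound 2 providing only a boundary beyond which no figure was recorded.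

The step of interest leads from compound 1 to compound 3, `C=C(Br)C(=O)Nc1cccc(-c2cn3nc(Cc4ccc(Cl)cc4)sc3n2)c1`. The change is 4-chlorobenzyl in place of 4-methylphenyl on an aromatic carbon. Among the compounds with values here, no step between two measured compounds is available to calibrate how this change behaves in this assay, so the expectation rests on compound 1 alone. The writer expects a modest weakening, somewhat beyond the scatter, so that the estimated step of a 2.7-fold higher number from compound 1 to compound 3 (0.43 log units; beyond the scatter) runs toward a higher value. Compound 3 is accordingly estimated at 2500 nM, with a range from 600 nM to 10000 nM.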

Compound 3, half-maximal inhibitory concentration: 2300 nM
For compound 3 the middle estimate is 1.1-fold (0.04 log units) above the measured one; measured number inside the range.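

In this assay, going by these compounds alone, the change to 4-chlorobenzyl gives a 2.5-fold higher number from compound 1 to compound 3 (0.40 log units; beyond the scatter), the first step that can be read at this position on the five-membered aromatic ring, and it is a modest one. It shows that the position accepts a different and longer-linked aryl group: compound 3 still gives a measured number rather than a limit of the assay, and it stays in the same general range as compound 1. The change alters two things at once, a chlorine taking the place of the methyl and a carbon link entering ahead of the six-membered ring, and no measurement shown here bears on why the step has this size.

From the compounds shown here alone, what remains open is how the step divides between those two parts, which 4-chlorophenyl or 4-methylbenzyl at the same position would address. Also open, going by these compounds, is how this position responds to a group of a different kind, such as an amine or a carboxylic acid on the six-membered ring, or to a longer chain in place of the single carbon link.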